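Sulfur-linked substituent variation on a shared core

The source may report more compounds than this note shows. Statements on the series, on what has been measured and on what is new or still open speak of the compounds shown alone.

Measured so far in a functional assay on MCF7 cells (Homo sapiens) for antiproliferative activity, read by MTT assay, with a stated time of 24 h; a lower number here means a stronger inhibitor, a higher number a weaker inhibitor:
Compound 1 `CSc1nnc(COc2cc(C)c3c(C)cc(=O)oc3c2)o1` gives > 100000 nM, a limit of the assay rather than a number.
Compound 2 `CCCCCCSc1nnc(COc2cc(C)c3c(C)cc(=O)oc3c2)o1` gives > 100000 nM, also a limit.
Compound 3 `Cc1cc(OCc2nnc(SCc3ccccc3)o2)cc2oc(=O)cc(C)c12` gives > 100000 nM, again a limit.

Compound 3 therefore stands at the same limit as the other two; the limit of > 100000 nM in this assay, at which 3 of the 3 values shown sit, sums up the whole picture. Every measured step is unreadable: a step that the two limits leave unreadable from compound 1 to compound 2, a step that the two limits leave unreadable from compound 1 to compound 3 and a step that the two limits leave unreadable from compound 2 to compound 3 give no size and no direction.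

Compound 4 `CCCCCCS(=O)(=O)c1nnc(COc2cc(C)c3c(C)cc(=O)oc3c2)o1` differs from compound 3 by hexylsulfonyl in place of benzylsulfanyl on an aromatic carbon. The change is not a single-place step among the measured pairs; the nearest points of comparison are compound 2, which carries the same hexyl chain on the sulfur, and compound 3 itself, both at the limit. Nothing measured shows that any change at this sulfur-bearing position moves the read-out off the limit, so the step from compound 3 to compound 4 is expected to be a step that the limit leaves unreadable from compound 3 to compound 4, most probably again unreadable. Compound 4 is expected to give about 150000 nM, in the range 40000 nM to 600000 nM.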

Compound 4, half-maximal inhibitory concentration: > 100000 nM
Compound 4 was reported as a limit; the forecaster's own chance of this, stated with the estimate: 85%; the middle value is on the limit's open side.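

In this assay, going by these compounds alone, compound 4 gives > 100000 nM, again a limit, so no step to it from compound 1, compound 2 or compound 3 can be read. The compounds shown leave open whether any substituent on the sulfur moves the read-out off this limit.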